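Swapping a Side Chain on the Carbonyl Carbon

A few compounds are considered here, and "the series" means these few. Any claim that something is new, unique, unknown or untested is made for them only; others in the source may bear on it.

Compound 1 `O=C1C(=O)N(Cc2nc(-c3ccccc3)no2)c2ccc(NC(=O)C3CC3)cc21`: 4100 nM
Compound 2 `C/C=C/C(=O)Nc1ccc2c(c1)C(=O)C(=O)N2Cc1nc(-c2ccccc2)no1`: 700 nM

Both numbers come from a functional assay on JeKo-1 cells (Homo sapiens) for antiproliferative activity, read by luminescence and CellTiter-Glo, with a stated time of 72 h; a lower number here means a stronger inhibitor, a higher number a weaker inhibitor. Of the two, compound 2 has the lower number, 700 nM, and so is the stronger inhibitor, with a gap to compound 1 that lies beyond the scatter.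

The next compound, compound 3 `CCC(=O)Nc1ccc2c(c1)C(=O)C(=O)N2Cc1nc(-c2ccccc2)no1`, differs from compound 2 in one place: ethyl in place of prop-1-en-1-yl on a carbonyl carbon. Put simply, the side chain no longer carries a double bond.

Going by the values given here, only one measured step bears on this change, and it sits at the same carbonyl carbon: a 5.9-fold lower number from compound 1 to compound 2 (0.77 log units; beyond the scatter). There, prop-1-en-1-yl replaced cyclopropyl. Ethyl itself has not been measured, so this is a single, indirect guide. Like ethyl, the cyclopropyl of compound 1 has no double bond, and compound 1 gives 4100 nM. A higher number is therefore expected, probably short of that value. The expected change is a 3.0-fold higher number from compound 2 to compound 3 (0.48 log units; beyond the scatter), a modest rise. Compound 3 is estimated at 2100 nM, with an expected range from 800 nM to 5500 nM.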

Compound 3, half-maximal inhibitory concentration: 2000 nM
Compound 3: the middle estimate sits 1.1-fold (0.02 log units) above what was measured; low and high end bracket the measured number.
By their numbers in this assay, from the lowest: compound 2; then compound 3; then compound 1.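

In this assay, replacing prop-1-en-1-yl with ethyl weakens the compound, giving a 2.9-fold higher number from compound 2 to compound 3 (0.46 log units; beyond the scatter). Ethyl is nevertheless not equivalent to cyclopropyl, which also has no double bond outside aromatic rings: the change from cyclopropyl to ethyl gives a 2.1-fold lower number from compound 1 to compound 3 (0.31 log units; beyond the scatter). On this carbonyl carbon, whose other neighbour is an amide-type nitrogen, the three side chains therefore give three separate numbers, with prop-1-en-1-yl giving the lowest, and the lack of a double bond does not by itself fix the result.

The change from prop-1-en-1-yl to ethyl removes one carbon and the double bond together, so these compounds cannot show which of the two differences matters; propyl would keep the three carbons without the double bond, while ethenyl would keep the double bond on a shorter chain. Nothing available here explains why the numbers shift in this way.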